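Nitro in Place of Trifluoromethyl: an Analogue Expected Inactive

The source may hold more compounds than are shown below. What is called first, only, known or untested is meant among the compounds shown, and "the series" means these compounds.

Compound 1 `CCC(COc1cccc(C(F)(F)F)c1)OC(=O)NCc1ccccc1` is the starting point. In an assay for inhibition of zeta-carotene desaturase, chloroplastic/chromoplastic (Capsicum annuum), using a Dixon plot, with a stated time of 8 h (a lower number here means a stronger inhibitor, a higher number a weaker inhibitor), compound 1 gives > 100000 nM, which is a limit of the assay and not a number. Two close relatives have been tested the same way. Compound 2 `CCC(COc1ccccc1Cl)OC(=O)NCc1ccccc1` carries a 2-chlorophenyl on an oxygen on a saturated carbon. In this assay compound 2 gives > 100000 nM, again only a limit. Compound 3 `CCC(COc1cccc(C#N)c1)OC(=O)NCc1ccccc1` has cyano in place of trifluoromethyl on an aromatic carbon. In this assay compound 3 gives > 100000 nM, a limit as well. Because every value sits at the limit of > 100000 nM in this assay, at which 3 of the 3 values shown sit, the steps cannot be sized: a step that the two limits leave unreadable from compound 1 to compound 3 and a step that the two limits leave unreadable from compound 2 to compound 3 both stay unreadable.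

Compound 4 `CCC(COc1cccc([N+](=O)[O-])c1)OC(=O)NCc1ccccc1` is the analogue still to be measured; it differs from compound 1 by nitro in place of trifluoromethyl on an aromatic carbon. Among the measured compounds shown here, the only measured step at the same position, a step that the two limits leave unreadable from compound 1 to compound 3, carries no readable size, so it offers no direction, and all three measured compounds remain beyond the reach of the assay. Compound 4 is therefore expected to stay at the limit too, with an estimated value of 200000 nM, between 100000 nM and 1000000 nM. The expected outcome is accordingly a step that the limit leaves unreadable from compound 1 to compound 4.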

Compound 4, half-maximal inhibitory concentration: > 100000 nM
Compound 4: a limit, no number (the forecaster's own chance of this, stated with the estimate: 85%); the middle value does not contradict the limit.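

Compound 4 also ends at a limit and not a number, so no step from compound 1 or compound 3 to compound 4 can be read: the limit of > 100000 nM in this assay, at which 4 of the 4 values shown sit.

The compounds shown leave open how strongly any of them inhibits the enzyme, and which change to the shared core, if any, would bring a value within reach of this assay.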